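A few compounds are considered here, and "the series" means these few. Any claim that something is new, unique, unknown or untested is made for them only; others in the source may bear on it.

Measured so far in a functional assay, with a stated time of 30 min; on this read-out lower numbers stand for stronger inhibition and higher numbers for weaker inhibition:
- compound 1 `CCOc1cc(OC)c(Br)cc1C(C)=O` gives 46800000 nM
- compound 2 `CCCCOc1cc(OC)c(Br)cc1C(C)=O` gives 42300000 nM
- compound 3 `CCCCCCOc1cc(OC)ccc1C(C)=O` gives 42600000 nM

Compound 1 and compound 2 share one core and differ by ethyl in place of hydrogen on a saturated chain carbon, two bonds along the chain from an oxygen on an aromatic ring. That change produced a 1.1-fold lower number from compound 1 to compound 2 (0.04 log units; within the scatter). Compound 3 stands on a different core; how the core of compound 3 differs from the core of compound 1 is not broken down here. In this assay compound 3 and compound 2 give numbers that lie within the scatter of one another, so nothing separates them.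

Compound 4 `CCCCCCCCOc1cc(OC)ccc1C(C)=O` has not yet been measured in this assay. It differs from compound 3 by ethyl in place of hydrogen on a saturated chain carbon, six bonds along the chain from an oxygen on an aromatic ring. Among the measured compounds shown here, this is the same kind of change as the one from compound 1 to compound 2, though not the same: in the earlier pair the entering ethyl sits two bonds along the chain from the oxygen on the aromatic ring, whereas in compound 4 it sits six bonds along the chain from that oxygen. Only one measured occurrence of this kind of change exists, and it is a 1.1-fold lower number from compound 1 to compound 2 (0.04 log units; within the scatter), which stayed within the scatter. For the measured compounds named here, on that basis a step of a 1.1-fold lower number from compound 3 to compound 4 (0.03 log units; within the scatter) is expected, essentially flat, with a wide range because the single precedent a 1.1-fold lower number from compound 1 to compound 2 (0.04 log units; within the scatter) comes from a different core and a different place on the chain. Compound 4 is accordingly estimated at 40000000 nM, expected to fall between 18000000 nM and 90000000 nM.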

Compound 4, half-maximal inhibitory concentration: 40000000 nM
Compound 4: middle estimate and measured number agree at the digits printed; the measured number falls inside the stated range.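

In this assay, ethyl in place of hydrogen on a saturated chain carbon, six bonds along the chain from an oxygen on an aromatic ring, gives a 1.1-fold lower number from compound 3 to compound 4 (0.03 log units; within the scatter). Set beside the earlier step, the same kind of change reads alike on the two cores, and in both cases it leaves the number within the scatter: the same change on two cores in this assay, a 1.1-fold lower number (0.04 log units; within the scatter) from compound 1 to compound 2 and a 1.1-fold lower number (0.03 log units; within the scatter) from compound 3 to compound 4, 1.0-fold (0.02 log units) apart, within the scatter of two such steps

This shows only that lengthening the chain by ethyl made no measurable difference in either of these two pairs; it does not show that the change would stay without effect on other cores or at other places on the chain, and the core and the place differ together between the pairs, so neither can be judged separately.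

Still open, going by these compounds, is whether a group of another kind, such as an amine or a carboxylic acid in place of the entering ethyl, would move the number beyond the scatter in this assay. Also open is whether the same ethyl step would stay within the scatter on a compound from this series with a much lower number than those seen here, since all four numbers shown lie close together.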